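A Halogenated Aniline in Place of a Methoxyphenyl

The compounds below may be only part of what the source reports. "The series", "measured", "known", "first", "only" and "open" are said of these compounds alone.

Compound 1 `COc1ccccc1Nc1nc(SCc2ccc(C(F)(F)F)cc2)nc2ccccc12` in a functional assay on MDA-MB-231 cells (Homo sapiens) for cytotoxicity, read by MTT assay, with a stated time of 72 h; a higher number here means a weaker inhibitor, a lower number a stronger inhibitor: > 50000 nM.
Compound 2 `COc1ccc(Nc2nc(SCc3ccc(C(F)(F)F)cc3)nc3ccccc23)c(OC)c1` in this assay: > 50000 nM.

In this assay compound 1 gives > 50000 nM, which is a limit of the assay and not a number. Compound 2 likewise gives > 50000 nM in this assay, again a limit. Among the measured compounds shown here, the only measured step, a step that the two limits leave unreadable from compound 1 to compound 2, is therefore unreadable in size, since both values sit at the limit of > 50000 nM in this assay, at which 2 of the 2 values shown sit. Compound 1 thus stands at the limit, with no numerical position within the assay.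

Compound 3 `Fc1ccc(Nc2nc(SCc3ccc(C(F)(F)F)cc3)nc3ccccc23)cc1Cl` is not yet measured. It differs from compound 1 as follows: 3-chloro-4-fluorophenyl in place of 2-methoxyphenyl on a nitrogen on an aromatic ring. For the measured compounds named here, no measured step bears directly on this change, and the one step that exists says nothing about its size. With compound 1 at > 50000 nM there is no evidence of any measurable potency on this core, so the step that the limit leaves unreadable from compound 1 to compound 3 is expected to leave compound 3 at or near the same limit. Compound 3 is accordingly estimated at 60000 nM, with a range from 20000 nM to 150000 nM, most likely reported only as a limit.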

Compound 3, half-maximal inhibitory concentration: 14500 nM
Compound 3: the middle estimate sits 4.1-fold (0.62 log units) above what was measured; the whole stated range lies above it.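

In this assay, the change at the nitrogen on an aromatic ring produces an at least 3.4-fold lower number from compound 1 to compound 3 (0.53 log units; beyond the scatter), and the same comparison with the 2,4-dimethoxyphenyl group gives an at least 3.4-fold lower number from compound 2 to compound 3 (0.53 log units; beyond the scatter). Among the compounds shown here, this is the first sign that the group at this place can affect the read-out on the shared core: compound 3 gives a real number, 14500 nM, whereas the earlier step between the two methoxy-bearing compounds cannot be read. Both new steps start from a limit of the assay, so they fix only a minimum size, and the two methoxy-bearing compounds still give no number: the limit of > 50000 nM in this assay, at which 2 of the 3 values shown sit.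

The compounds shown leave open whether the step belongs to the chlorine, to the fluorine, to their combination or simply to the loss of methoxy, as all of these change together in compound 3. They also leave open how a nitrile, a carboxylic acid or an amine on this phenyl ring would compare with the 3-chloro-4-fluorophenyl group.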